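Working notes: from compound 3 to compound 4

A few compounds are considered here, and "the series" means these few. Any claim that something is new, unique, unknown or untested is made for them only; others in the source may bear on it.

Compound 1 `Cc1cc(Nc2cc(-c3ccccc3)[nH]n2)n2nc(SCc3ccc(F)cc3)nc2n1`: 4020 nM
Compound 2 `Cc1cc(Nc2cc(-c3cccs3)[nH]n2)n2nc(SCc3ccc(Br)cc3)nc2n1`: 5370 nM
Compound 3 `Cc1cc(Nc2cc(-c3ccccc3)[nH]n2)n2nc(SCC3CCCCC3)nc2n1`: > 50000 nM, a limit of the assay

All three were tested in a functional assay on MCF7 cells (Homo sapiens) for inhibition, read by MTT assay, with a stated time of 72 h; a higher number here means a weaker inhibitor, a lower number a stronger inhibitor. Compound 3 stands at > 50000 nM, which is a limit and not a number. The series holds (the limit of > 50000 nM in this assay, at which 1 of the 3 values shown sits).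

Compound 4 `Cc1cc(Nc2cc(-c3ccccc3)[nH]n2)n2nc(SCc3ccc(Br)cc3)nc2n1` carries 4-bromophenyl in place of cyclohexyl on a saturated chain carbon bound to a sulfur.

Among the compounds with values here, the one measured step that bears directly on this is an at least 12-fold higher number from compound 1 to compound 3 (1.09 log units; beyond the scatter), where cyclohexyl replaces 4-fluorophenyl at the same place. The change to compound 4 runs the opposite way, so a large step to a lower number is expected, of a size left open by the limit. Compound 2 also carries the 4-bromophenyl group and gives 5370 nM, though it differs from compound 4 elsewhere. The expected change is an at least 11-fold lower number from compound 3 to compound 4 (1.04 log units; beyond the scatter). For compound 4 the estimated value is 4500 nM, with an expected range of 1500 nM to 13000 nM.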

Compound 4, half-maximal inhibitory concentration: 2720 nM
The estimate for compound 4 lay 1.7-fold (0.22 log units) above the measured number; the measured number falls inside the stated range.
By their numbers in this assay, from the lowest: compounds 4, 1 and 2 (each within the scatter of the next). At a limit, above all of these: compound 3.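

In this assay, 4-bromophenyl in place of cyclohexyl on a saturated chain carbon bound to a sulfur gives an at least 18-fold lower number from compound 3 to compound 4 (1.26 log units; beyond the scatter), so the large step seen with the 4-fluorophenyl pair now appears with a second aromatic group. Compound 3 stands at a limit of the assay, so this step is only a bound: the limit of > 50000 nM in this assay, at which 1 of the 4 values shown sits. Bromo in place of fluoro gives a 1.5-fold lower number from compound 1 to compound 4 (0.17 log units; within the scatter), and phenyl in place of thiophen-2-yl gives a 2.0-fold lower number from compound 2 to compound 4 (0.30 log units; within the scatter), so neither change separates these compounds.

Open, on these data alone, is whether the aromatic ring itself is what matters here, as a pyridine ring at this place would begin to show. Also open, as far as these compounds go, is how a carboxylic acid or an amine in place of the bromo, or a longer chain to the sulfur, would read.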